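Chloro in Place of Methyl on the Carbonyl Aryl Ring

The source may hold more compounds than are shown below. What is called first, only, known or untested is meant among the compounds shown, and "the series" means these compounds.

Compound 1 `COc1cc(C(=O)C2Sc3nnc(-c4cc(OC)c(OC)c(OC)c4)n3NC2c2ccco2)cc(OC)c1OC` gives 48300 nM in a functional assay on A549 cells (Homo sapiens) for cytotoxicity, read by MTT assay, with a stated time of 48 h; a lower number here means a stronger inhibitor, a higher number a weaker inhibitor.
Compound 2 `COc1cc(-c2nnc3n2NC(c2cccs2)C(C(=O)c2ccc(C)cc2)S3)cc(OC)c1OC` gives 12700 nM in this assay.
Compound 3 `COc1cc(-c2nnc3n2NC(c2ccco2)C(C(=O)c2ccc(C)cc2)S3)cc(OC)c1OC` reaches only a limit of this assay, > 100000 nM.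

Of the two numbers, compound 2 holds the lower one. Compound 4 `COc1cc(-c2nnc3n2NC(c2cccs2)C(C(=O)c2ccc(Cl)cc2)S3)cc(OC)c1OC` differs from compound 2 by chloro in place of methyl on an aromatic carbon. Within the data shown here, no measured step tests chloro against methyl; the carbonyl aryl ring is touched only by an at least 2.0-fold higher number from compound 1 to compound 3 (0.31 log units; beyond the scatter), while an at least 7.8-fold higher number from compound 2 to compound 3 (0.89 log units; beyond the scatter) concerns a different ring, and the limit of > 100000 nM in this assay, at which 1 of the 3 values shown sits, makes both of those steps lower bounds. Given that, a step of only modest size is expected in this assay, a 1.1-fold lower number from compound 2 to compound 4 (0.02 log units; within the scatter). Compound 4 is therefore estimated at 12000 nM, between 4000 nM and 40000 nM.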

Compound 4, half-maximal inhibitory concentration: 20100 nM
The estimate for compound 4 lay 1.7-fold (0.22 log units) below the measured number, and the stated range covers the measured number.
By their numbers in this assay, from the lowest: compounds 2 and 4 (each within the scatter of the next); then compound 1. At a limit, above all of these: compound 3.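

The first direct test at this place on the carbonyl aryl ring, para to a large group, holds the thiophen-2-yl group fixed and gives a step within the scatter (a 1.6-fold higher number from compound 2 to compound 4 (0.20 log units; within the scatter)). Thus, 4-chlorophenyl and 4-methylphenyl cannot be told apart here in this assay, whereas the earlier change on this ring (an at least 2.0-fold higher number from compound 1 to compound 3 (0.31 log units; beyond the scatter)) gave only a lower bound and replaced a 3,4,5-trimethoxyphenyl group. Nothing shown accounts for the size of this step.

On these data alone, whether chloro and methyl also match alongside furan-2-yl remains open. So does how an amine or a carboxylic acid at this place would read in this assay.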